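From 3-fluorophenyl to hydroxy: an expected loss of growth inhibition

This account rests on a few compounds, and the source may have more. Where it says the series, first, only, none or still open, it means among the compounds named here.

Compound 1 `COc1cc(/C=C/C(=O)/C=C/c2sccc2C)cc(OC)c1OC` gives 9310 nM
Compound 2 `COc1ccc(/C=C/C(=O)C(=Cc2cccc(F)c2)C(=O)/C=C/c2ccc(OC)c(OC)c2)cc1OC` gives 580 nM
Compound 3 `COc1cc(/C=C/C(=O)C(=Cc2cccc(F)c2)C(=O)/C=C/c2ccc(O)c(OC)c2)ccc1O` gives 360 nM

All three values come from a functional assay on A549 cells (Homo sapiens) for inhibition, read by sulforhodamine B assay, with a stated time of 48 h (a higher number here means a weaker inhibitor of growth, a lower number a stronger inhibitor of growth), and no two of these compounds differ in only one place. Compound 2 gives 580 nM and stands within the scatter of compound 3 (360 nM) but well apart from compound 1 (9310 nM) whose number is higher, beyond the scatter.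

Compound 4 `COc1ccc(/C=C/C(=O)C(=CO)C(=O)/C=C/c2ccc(OC)c(OC)c2)cc1OC` has not yet been measured. It carries hydroxy in place of 3-fluorophenyl on a double-bonded chain carbon bound to a double-bonded chain carbon and is otherwise identical to compound 2. Going by the values given here, no measured pair shows this change, and the expectation rests on thin evidence. Compound 2 and compound 3 both carry the 3-fluorophenyl group, while compound 1 (9310 nM) has none, although it also differs from them elsewhere. On that single contrast, a higher number is expected for compound 4. The estimated step is a 5.2-fold higher number from compound 2 to compound 4 (0.71 log units; beyond the scatter) in this assay and is expected to point toward a weaker inhibitor of growth, beyond the scatter. For compound 4 the estimated value is 3000 nM with an expected range from 800 nM to 11000 nM in this measurement.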

Compound 4, concentration for 50% growth inhibition: > 25000 nM
Compound 4 was reported as a limit; the forecaster's own chance of this, stated with the estimate: 5%; at least 8.3-fold (0.92 log units) between middle value and limit.
By their numbers in this assay, from the lowest: compounds 3 and 2 (each within the scatter of the next); then compound 1. At a limit, above all of these: compound 4.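

Going by these compounds alone, this pair gives the first direct reading of this position, since no two earlier compounds differed in only one place. With hydroxy in place of 3-fluorophenyl on a double-bonded chain carbon bound to a double-bonded chain carbon, and everything else unchanged, this assay shows an at least 43-fold higher number from compound 2 to compound 4 (1.63 log units; beyond the scatter), so growth inhibition at this position depends strongly on what is carried there. The value of compound 4 is a limit, which gives the step a lower bound but no upper end: the limit of > 25000 nM in this assay, at which 1 of the 4 values shown sits.

The change removes an aromatic ring and adds hydroxy in one move, so this single pair cannot say whether the loss follows from the departure of 3-fluorophenyl or from the arrival of hydroxy. Unfluorinated phenyl, a methyl group or an amine at the same carbon would help to separate those readings, and the compounds shown also leave open whether the same exchange would have a similar effect on compound 3.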